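From an Acetylphenoxy Chain to a Phenylsulfonyl Chain

A few compounds are considered here, and "the series" means these few. Any claim that something is new, unique, unknown or untested is made for them only; others in the source may bear on it.

Of the compounds shown here, three have been measured in a functional assay (aorta) with Oryctolagus cuniculus as the target; a lower number here means tighter binding, a higher number weaker binding. Compound 1 `COc1cc(C(C)=O)ccc1OCCCN1CCC(C(c2ccccc2)c2ccccc2)CC1` gives 6.31 nM. Compound 2 `COc1cc(C(C)=O)ccc1OCCCN1CCC(C(c2ccc(Cl)cc2)c2ccc(Cl)cc2)CC1` gives 2.51 nM. Compound 3 `CC(=O)c1ccc(OCCCN2CCC(C(c3ccc(F)cc3)c3ccc(F)cc3)CC2)cc1` gives 2.51 nM. On these numbers compound 3 stands level with compound 2 at the digits shown, the two together holding the lowest numbers of the three, while compound 1 sits furthest away with a higher number that lies beyond the usual scatter of repeat measurements. Among the measured compounds shown here, no two of these three differ in only one place, so no single step has been quantified among them; what compound 1, compound 2 and compound 3 show is simply their three values.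

The next compound, compound 4 `O=S(=O)(CCCN1CCC(C(c2ccc(F)cc2)c2ccc(F)cc2)CC1)c1ccccc1`, has not yet been measured in this assay. It differs from compound 3 in one place: phenylsulfonyl in place of 4-acetylphenoxy on a saturated chain carbon, three bonds along the chain from an amine nitrogen in a ring. For the measured compounds named here, no measured pair makes this exchange, so the expectation rests on the structural change alone. Compound 4 is expected to give 8 nM in this assay, with a range from 2.5 nM to 25 nM. The step that this expectation means, a 3.2-fold higher number from compound 3 to compound 4 (0.50 log units; beyond the scatter), is expected to run toward a higher number, a modest weakening that may only just exceed the scatter.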

Compound 4, dissociation constant: 20 nM
Compound 4: middle estimate off by 2.5-fold (0.40 log units), on the low side; measured number inside the range.
By their numbers in this assay, from the lowest: compounds 2 and 3 (each within the scatter of the next); then compound 1; then compound 4.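

In this assay, among the compounds shown here, putting phenylsulfonyl in place of 4-acetylphenoxy on a saturated chain carbon, three bonds along the chain from an amine nitrogen in a ring, gives an 8.0-fold higher number from compound 3 to compound 4 (0.90 log units; beyond the scatter) and so provides the first single change in this set whose size can be read. The position is therefore not indifferent to what is attached there, even though the two groups match in several counted features: each has one six-membered aromatic ring of carbon only, no hydrogen-bond donors and the same number of hydrogen-bond acceptors, so these shared counts do not guarantee a matching number. No measurement shown here explains why the number moves with this exchange.

On these data alone, this one step changes several things together, so it remains open whether the acetyl group or the link between the chain and the aromatic ring accounts for the rise. A plain phenoxy group or a 4-acetylphenylsulfonyl group on the same chain would help separate those two parts, and a longer chain would test how much the distance from the ring nitrogen matters.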